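Cytotoxicity notes: extending the urea of compound 3

A few compounds are considered here, and "the series" means these few. Any claim that something is new, unique, unknown or untested is made for them only; others in the source may bear on it.

Compound 1 `COc1cc(NC(C)CCCNC(=O)/C=C/c2ccccc2)c2ncccc2c1` serves as the reference point of this set. In an ADME assay on L6 cells (Rattus norvegicus) for cytotoxicity, read by resazurin assay, with a stated time of 70 h (a lower number here means a stronger inhibitor, a higher number a weaker inhibitor), compound 1 gives 7.2 ug/mL. Compound 2 `COc1ccc(/C=C/C(=O)NCCCC(C)Nc2cc(OC)cc3cccnc23)cc1` differs from it by a single methoxy group. Compound 2 reaches only a limit in this assay, > 100 ug/mL. Compound 3 `COc1cc(NC(C)CCCNC(=O)Nc2cccc(F)c2)c2ncccc2c1` replaces the cinnamoyl part of compound 1 with a fluorophenyl urea; in this assay compound 3 gives 9.18 ug/mL. Within the data shown here, compound 3 thus stands highest of the two plain numbers, with compound 1 nearest, and the only other value is a limit. The steps seen so far are an at least 13-fold higher number from compound 1 to compound 2 (1.14 log units; beyond the scatter), a 1.3-fold higher number from compound 1 to compound 3 (0.11 log units; within the scatter) and an at least 10-fold lower number from compound 2 to compound 3 (1.03 log units; beyond the scatter); the two large ones both involve compound 2, which sits at the limit of > 100 ug/mL in this assay, at which 1 of the 3 values shown sits.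

Compound 4 `COc1cc(NC(C)CCCNC(=O)NNC(=O)Nc2cccc(Br)c2)c2ncccc2c1` is the next member. The change from compound 3 is ((3-bromophenyl)carbamoyl)amino in place of 3-fluorophenyl on an amide-type nitrogen. Among the measured compounds shown here, no measured step touches this part of the molecule in the same way: the step from compound 1 to compound 3 swapped the carbonyl substituent without shifting the number beyond the scatter, whereas the large steps concern a ring methoxy. A modest step towards a higher number, or none beyond the scatter, is therefore expected, written as a 2.0-fold higher number from compound 3 to compound 4 (0.29 log units; within the scatter). For compound 4 the estimated value in this assay is 18 ug/mL, within 6 ug/mL to 60 ug/mL.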

Compound 4, half-maximal inhibitory concentration: 20 ug/mL
Beside the measured number, compound 4's estimate is 1.1-fold (0.05 log units) below it; measured number inside the range.
By their numbers in this assay, from the lowest: compounds 1 and 3 (each within the scatter of the next); then compound 4. At a limit, above all of these: compound 2.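

In this assay, the change on the amide-type nitrogen gives a 2.2-fold higher number from compound 3 to compound 4 (0.34 log units; beyond the scatter), a modest step and the first one in this set at this position. The earlier compounds shown here varied only the group on the carbonyl carbon, whereas here ((3-bromophenyl)carbamoyl)amino, with its 11 heavy atoms, 2 hydrogen-bond donors and 1 hydrogen-bond acceptor, replaces 3-fluorophenyl, with its 7 heavy atoms and no donors or acceptors, and the result remains a plain number rather than a limit. This single step swaps fluorine for bromine and also inserts the extra carbamoyl amino stretch, and no measurement shown bears on why the number moves.

Among these compounds, how much of the step belongs to the halogen and how much to the added stretch stays open, as the two change together in the only pair available at this position. Equally open, on these data alone, is how the number in this assay would respond to a carboxylic acid or a primary amine on the phenyl ring of the entering group, or to a longer chain in place of the added stretch.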